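A few compounds are considered here, and "the series" means these few. Any claim that something is new, unique, unknown or untested is made for them only; others in the source may bear on it.

Measured so far in a physicochemical assay for lipophilicity, at pH 7.4; a lower number here means a more polar compound, a higher number a more lipophilic compound:
compound 1, `O=C(Nc1ccnnc1)c1cc(N2CCNCC2)ccc1OCc1ccccc1`, 1.9;
compound 2, `O=C(Nc1ccnnc1)c1cc(N2CCC(F)CC2)ccc1OCc1ccccc1`, 5.1;
compound 3, `CN1CCC(c2ccc(OCc3ccccc3)c(C(=O)Nc3ccnnc3)c2)CC1`, 2.3.

Compound 3 stands second highest of the three numbers: a number 0.40 log units higher from compound 1 to compound 3 (beyond the scatter), while a number 2.80 log units lower from compound 2 to compound 3 (beyond the scatter). Compound 4, `O=C(Nc1ccnnc1)c1cc(N2C[C@H]3COC[C@H]3C2)ccc1OCc1ccccc1`, is not yet measured. Relative to compound 3, (a group of 8 heavy atoms (6 carbon, 1 nitrogen, 1 oxygen; 2 five-membered non-aromatic rings with 1 hetero atom each) in place of a group of 7 heavy atoms (6 carbon, 1 nitrogen; one six-membered non-aromatic ring with 1 hetero atom), on an aromatic carbon). The entering group, like the 4-fluoropiperidin-1-yl of compound 2, joins the aromatic carbon through its nitrogen, whereas the 1-methylpiperidin-4-yl of compound 3 joins through carbon. Among the compounds with values here, the steps that bear on this are large: a number 3.20 log units higher from compound 1 to compound 2 (beyond the scatter) and a number 2.80 log units lower from compound 2 to compound 3 (beyond the scatter). A large rise in this assay is therefore expected, though the entering group counts 2 hydrogen-bond acceptors against 1 in the leaving group, which argues for a step short of those. Compound 4 is estimated at 4, within 3.3 to 4.7, an expected step of a number 1.70 log units higher from compound 3 to compound 4 (beyond the scatter).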

Compound 4, distribution coefficient: 4.5
Compound 4: the middle estimate sits 0.50 log units below what was measured, within the range that was stated.
By their numbers in this assay, from the lowest: compound 1; then compound 3; then compound 4; then compound 2.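

With this assay as the read-out, the group with 2 five-membered non-aromatic rings, joined through nitrogen, gives a number 2.20 log units higher from compound 3 to compound 4 (beyond the scatter) and a number 2.60 log units higher from compound 1 to compound 4 (beyond the scatter), so a high number at this position survives 2 hydrogen-bond acceptors in the entering group. The gap to the fluorinated group is smaller, a number 0.60 log units lower from compound 2 to compound 4 (beyond the scatter), yet joining through nitrogen does not alone set the number, since compound 1 also joins through nitrogen and stands lowest. No available evidence accounts for these steps. Open, from the compounds shown here alone, is where morpholin-4-yl would fall at this position, and whether the opposite stereocentres in the entering group would shift the number.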